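The source may hold more compounds than are shown below. What is called first, only, known or untested is meant among the compounds shown, and "the series" means these compounds.

Within the data shown here, compound 2 `Nc1nc(-c2cccc(F)c2)nc2sc(Cc3ccccc3)cc12` stands as the lowest of the two numbers measured so far in a functional assay on CHO-K1 cells for antagonist activity at adenosine receptor A1 (Homo sapiens), read by a beta-galactosidase reporter and cAMP accumulation, with stated times of 15 min and 6 h (on this read-out lower numbers stand for stronger inhibition and higher numbers for weaker inhibition), where compound 2 gives 123 nM. Among the measured compounds shown here, its nearest neighbour is compound 1 `Nc1nc(-c2ncco2)nc2sc(Cc3ccccc3)cc12`, which in this assay gives 310 nM; the only measured step, a 2.5-fold lower number from compound 1 to compound 2 (0.40 log units; beyond the scatter), came with 3-fluorophenyl in place of 1,3-oxazol-2-yl on an aromatic carbon. Compound 3 `COc1cccc(-c2nc(N)c3cc(Cc4ccccc4)sc3n2)c1` differs from compound 2 by methoxy in place of fluoro on an aromatic carbon. For the measured compounds named here, no measured step bears on this change: the step from compound 1 to compound 2 exchanged one ring for another and tells nothing about swapping a small group on that ring. Going by the values given here, with no comparable step available, the expected change in this assay is none beyond the scatter, so the estimated step is a 1.2-fold higher number from compound 2 to compound 3 (0.09 log units; within the scatter). Compound 3 is therefore expected to give about 150 nM in this assay, with a likely range from 60 nM to 400 nM.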

Compound 3, inhibition constant: 266 nM
Estimate against measurement, compound 3: 1.8-fold (0.25 log units) below; low and high end bracket the measured number.
By their numbers in this assay, from the lowest: compound 2; then compounds 3 and 1 (each within the scatter of the next).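

The group carried on the phenyl ring at this position of the shared core matters in this assay: methoxy in place of fluoro gives a 2.2-fold higher number from compound 2 to compound 3 (0.33 log units; beyond the scatter), a modest change beyond the scatter. Replacing 1,3-oxazol-2-yl with 3-methoxyphenyl gives only a 1.2-fold lower number from compound 1 to compound 3 (0.07 log units; within the scatter), within the scatter, so the advantage that 3-fluorophenyl showed over 1,3-oxazol-2-yl does not extend to this second phenyl ring. No measurement given here accounts for the difference between fluoro and methoxy.

Going by these compounds, only these two groups on the phenyl ring can be compared, so it remains open how chloro, hydroxy or an amine at the same place would compare with them. On these data alone, it also remains open whether methoxy in place of fluoro would give a step of similar size on a different core.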